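Swapping fluoro for hydroxy in a stable compound

This account rests on a few compounds, and the source may have more. Where it says the series, first, only, none or still open, it means among the compounds named here.

Values in an ADME assay on microsomes from liver (Homo sapiens) for metabolic stability, with a stated time of 10 min; a higher number here means that more of the compound is left, a lower number that less of the compound is left:
- Compound 1 `CC[C@]1(C(=O)O)CC[C@H](C(=O)N2CC[C@](c3ccc(C(F)(C(F)(F)F)C(F)(F)F)cc3)(S(=O)(=O)c3ccc(F)cc3)C2)CC1`: 100%
- Compound 2 `O=C(N1CC[C@](c2ccc(C(F)(C(F)(F)F)C(F)(F)F)cc2)(S(=O)(=O)c2ccc(F)cc2)C1)C1(F)CCS(=O)(=O)CC1`: 100%

Compound 2 stands level with compound 1 on these numbers, so neither can be ranked above the other. The next structure, compound 3 `O=C(N1CC[C@](c2ccc(C(F)(C(F)(F)F)C(F)(F)F)cc2)(S(=O)(=O)c2ccc(F)cc2)C1)C1(O)CCS(=O)(=O)CC1`, keeps everything in compound 2 except one group: hydroxy in place of fluoro on a saturated ring carbon. This is hydroxy in place of fluoro on a saturated ring carbon, three ring bonds from the ring sulfur.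

Among the measured compounds shown here, no measured pair shows this exact exchange, so the evidence is indirect. For the measured compounds named here, the only measured step bearing on it replaced a much larger group on a carbonyl carbon, putting 4-fluoro-1,1-dioxothian-4-yl in place of 4-carboxy-4-ethylcyclohexyl. Its size was no change at the digits printed from compound 1 to compound 2 (within the scatter). That one step suggests that this series can tolerate change in this part of the structure, although it cannot show how a hydroxy group will behave. A step beyond the scatter is therefore not expected, and the expected step is a number 4 percentage points lower from compound 2 to compound 3 (within the scatter). For compound 3, the estimated value is 96%, with an expected range of 85% to 100%.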

Compound 3, percent of the compound remaining: 100%
Compound 3: middle estimate off by 4 percentage points, on the low side, and the stated range covers the measured number.
By their numbers in this assay, from the lowest: compounds 1, 2 and 3 (each within the scatter of the next).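

In this assay, putting hydroxy in place of fluoro on a saturated ring carbon, three ring bonds from the ring sulfur, gives no change at the digits printed from compound 2 to compound 3 (within the scatter), so at this position the oxygen-bearing group holds up as well as the fluorine did. Compound 2 had shown only that the 4-fluoro-1,1-dioxothian-4-yl group could take the place of the larger 4-carboxy-4-ethylcyclohexyl group, and the hydroxy version now does the same, with no change at the digits printed from compound 1 to compound 3 (within the scatter) as the result. Nothing available explains why the exchange leaves this read-out untouched.

All three compounds sit at the same top reading, so this test cannot rank compound 1, compound 2 and compound 3, and any real difference between them would only show under harsher conditions, such as a longer incubation. Whether a methoxy group, an amine or a carboxylic acid on the same ring carbon would leave the reading just as high remains an open question.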